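This account rests on a few compounds, and the source may have more. Where it says the series, first, only, none or still open, it means among the compounds named here.

In a functional assay on SK-MEL-28 cells (Homo sapiens) for cytotoxicity, read by CCK-8 assay, with a stated time of 24 h (a lower number here means a stronger inhibitor, a higher number a weaker inhibitor), three compounds sharing one core have been measured:

compound 1 `COc1ccccc1Oc1c(N)nc(-c2cccc(F)c2)nc1OCCO`: 3210 nM
compound 2 `COc1ccccc1Oc1c(N)nc(-c2cccc(Cl)c2)nc1OCCO`: 4170 nM
compound 3 `COc1ccccc1Oc1c(N)nc(-c2ccc(Br)cc2)nc1OCCO`: 4400 nM

Compound 3 cannot be separated from the other two, as the measured steps to it are a 1.1-fold higher number from compound 2 to compound 3 (0.02 log units; within the scatter) and a 1.4-fold higher number from compound 1 to compound 3 (0.14 log units; within the scatter). Compound 4 `COc1ccccc1Oc1c(N)nc(-c2cccc(I)c2)nc1OCCO` has not yet been measured. It differs from compound 3 by 3-iodophenyl in place of 4-bromophenyl on an aromatic carbon, with 3-iodophenyl in place of 4-bromophenyl on an aromatic carbon.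

Each measured step likewise exchanges one halogen-bearing phenyl group for another. Besides the two steps above, there is a 1.3-fold higher number from compound 1 to compound 2 (0.11 log units; within the scatter), and none of the three leaves the scatter. Among the compounds with values here, no iodo compound has been measured, so this rests on the lighter halogens alone. In this assay, no step beyond the scatter is therefore expected, in either direction. The estimated step is a 1.0-fold lower number from compound 3 to compound 4 (0.02 log units; within the scatter). For compound 4 the expected value is 4200 nM, with an estimated range from 2400 nM to 7200 nM.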

Compound 4, half-maximal inhibitory concentration: 11200 nM
Estimate against measurement, compound 4: 2.7-fold (0.43 log units) below, and the stated range ends below it.
By their numbers in this assay, from the lowest: compounds 1, 2 and 3 (each within the scatter of the next); then compound 4.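

In this assay, the halogen-bearing phenyl group on the aromatic carbon between two ring nitrogen atoms proves not to be freely exchangeable: iodo in place of chloro gives a 2.7-fold higher number from compound 2 to compound 4 (0.43 log units; beyond the scatter), and iodo in place of fluoro gives a 3.5-fold higher number from compound 1 to compound 4 (0.54 log units; beyond the scatter). Within the data shown here, the change of 4-bromophenyl to 3-iodophenyl gives a 2.5-fold higher number from compound 3 to compound 4 (0.41 log units; beyond the scatter), so compound 4 is the first compound here to stand beyond the scatter of the others, and it does so on the weaker side. No available evidence bears on why this step occurs.

A 3-bromophenyl or a 4-iodophenyl group would help show whether this shift follows the iodine itself or the place of the halogen on the phenyl ring. From the compounds shown here alone, how a methoxy group, an amine or a carboxylic acid on that ring would read remains open.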